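A Change on the Ring Nitrogen of Compound 1

The source may hold more compounds than are shown below. What is called first, only, known or untested is meant among the compounds shown, and "the series" means these compounds.

Measured so far:
compound 1 `COc1ccc([C@@H]2C/C(=N/OCc3cn(-c4ccccc4CO)nn3)c3cc(CC=C(C)C)c(OC)cc3O2)cc1`: 100%
compound 2 `COc1cc2c(cc1CC=C(C)C)C(=O)C[C@@H](c1ccc(Oc3ccccc3)cc1)O2`: 69%
compound 3 `COc1ccc([C@@H]2C/C(=N/O)c3cc(CC=C(C)C)c(OC)cc3O2)cc1`: 63%

All three compounds were tested in a functional assay on MCF7 cells (Homo sapiens) for inhibition, read by sulforhodamine B assay, with a stated time of 48 h, tested at 50 uM; a higher number here means more inhibition of growth at the concentration tested, a lower number less inhibition of growth. Compound 1 stands highest of the three numbers with 100%. The nearest is compound 2 at 69%, a gap beyond the usual scatter, and the furthest is compound 3 at 63%, also beyond the scatter. No two of these compounds differ in only one place, so no single structural step can be read from them.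

Compound 4 `COc1ccc([C@@H]2C/C(=N/OCc3cn(-c4ccc(C(N)=O)cc4)nn3)c3cc(CC=C(C)C)c(OC)cc3O2)cc1` is the next compound, made from compound 1 by one change: 4-carbamoylphenyl in place of 2-(hydroxymethyl)phenyl on an aromatic nitrogen. Since compound 1 already sits at the top of the scale, the step in this assay can only hold level or move down. Within the data shown here, with no comparable step among the measured compounds to lean on, a small downward step, within the scatter, is expected, because compound 1 gives 100% and the group that enters resembles the one that leaves in size and in its donor and acceptor count. The expected step is a number 10 percentage points lower from compound 1 to compound 4 (within the scatter). Compound 4 is estimated at 90%, between 65% and 100%.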

Compound 4, percent growth inhibition at one concentration: 100%
The estimate for compound 4 lay 10 percentage points below the measured number; low and high end bracket the measured number.
By their numbers in this assay, from the lowest: compounds 3 and 2 (each within the scatter of the next); then compounds 1 and 4 (each within the scatter of the next).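

In this assay, putting 4-carbamoylphenyl in place of 2-(hydroxymethyl)phenyl on the aromatic nitrogen gives no change at the digits printed from compound 1 to compound 4 (within the scatter), the first single-place comparison available in this set. This position therefore accepts either of these two substituted phenyl groups without a measurable loss, although both compounds sit at the top of the scale, so a single test concentration cannot separate them. Nothing available here explains why the two groups give the same reading.

From the compounds shown here alone, whether compound 1 and compound 4 would still match at lower concentrations remains open, as a full dose-response comparison could show a difference that is hidden here. Going by these compounds, it is also open whether a phenyl ring bearing a carboxylic acid or an amine, or a plain butyl chain in place of the ring, would hold the same reading.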